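Benzyl oxime ether and tolerance by Vero cells

The compounds below may be only part of what the source reports. "The series", "measured", "known", "first", "only" and "open" are said of these compounds alone.

Compound 2 `CCO/N=C(\C)CCN1CCN(c2nc(=O)c3cc(C(F)(F)F)cc([N+](=O)[O-])c3s2)CC1` was tested in an ADME assay on Vero cells (Chlorocebus sabaeus) for cytotoxicity; a higher number here means that more compound is tolerated, a lower number that less compound is tolerated. In this assay compound 2 reaches only the limit > 64 ug/mL, not a number. Compound 1 `CCO/N=C(\C)CN1CCN(c2nc(=O)c3cc(C(F)(F)F)cc([N+](=O)[O-])c3s2)CC1` likewise stops at the limit > 64 ug/mL in this assay. The step that the two limits leave unreadable from compound 1 to compound 2 cannot be read, since both values sit at the limit (the limit of > 64 ug/mL in this assay, at which 2 of the 2 values shown sit). Compound 3 `C/C(CCN1CCN(c2nc(=O)c3cc(C(F)(F)F)cc([N+](=O)[O-])c3s2)CC1)=N\OCc1ccccc1` differs from compound 2 by phenyl in place of methyl on a saturated chain carbon bound to an oxygen on an unsaturated carbon, or, cut one bond further out, ethoxy to benzyloxy. Among the measured compounds shown here, no measured step bears on this change, so no direction beyond the scatter is expected. Compound 3 is therefore estimated at 60 ug/mL, within 25 ug/mL to 128 ug/mL. The expected step is an at least 1.0-fold lower number from compound 2 to compound 3 (0.02 log units; that floor lies within the scatter).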

Compound 3, half-maximal cytotoxic concentration: > 64 ug/mL
Compound 3: no number, only a limit; the forecaster's own chance of this, stated with the estimate: 55%; middle value at least 1.0-fold (0.02 log units) away from the limit.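

Compound 3 gives only a limit, as do compound 1 and compound 2, so no step among these compounds can be read: the limit of > 64 ug/mL in this assay, at which 3 of the 3 values shown sit.

As far as these compounds go, whether benzyloxy in place of ethoxy makes any difference in this assay stays open, as does the actual number for each compound.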